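The source may hold more compounds than are shown below. What is called first, only, known or untested is meant among the compounds shown, and "the series" means these compounds.

Compound 1 `O=C1c2c[n+]([O-])c3ccccc3c2C(=O)c2c1c1ccccc1n2Cc1cn([C@H]2O[C@H](CO)[C@@H](O)[C@H]2O)nn1`: 1490 nM
Compound 2 `O=C1c2c[n+]([O-])c3ccccc3c2C(=O)c2c1c1ccccc1n2CCN1CCCC1`: 320 nM
Compound 3 `CCCCN1CCN(CCCCn2c3c(c4ccccc42)C(=O)c2c[n+]([O-])c4ccccc4c2C3=O)CC1`: 6900 nM

In a functional assay on MCF7 cells (Homo sapiens) for cytotoxicity, read by MTT assay, with a stated time of 72 h (a lower number here means a stronger inhibitor, a higher number a weaker inhibitor), compound 1 gives 1490 nM, the middle of the three numbers, with compound 2 lower and compound 3 higher. Compound 4 `CC1(C)O[C@@H](CO)[C@H](Cn2cc(Cn3c4c(c5ccccc53)C(=O)c3c[n+]([O-])c5ccccc5c3C4=O)nn2)O1` departs from compound 1 by (5-(hydroxymethyl)-2,2-dimethyl-1,3-dioxolan-4-yl)methyl in place of 3,4-dihydroxy-5-(hydroxymethyl)oxolan-2-yl on an aromatic nitrogen. Among the measured compounds shown here, the only measured step is a 22-fold higher number from compound 2 to compound 3 (1.33 log units; beyond the scatter), and it concerns a different group at a different place, so it bears on this change only loosely. It shows that large steps can occur in this series, but it gives no direction for compound 4. The expected step is therefore a 1.1-fold lower number from compound 1 to compound 4 (0.03 log units; within the scatter), with no change beyond the scatter anticipated. Compound 4 is estimated at 1400 nM, with an expected range of 400 nM to 5500 nM.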

Compound 4, half-maximal inhibitory concentration: 690 nM
Compound 4: middle estimate off by 2.0-fold (0.31 log units), on the high side, and the stated range covers the measured number.
By their numbers in this assay, from the lowest: compound 2; then compound 4; then compound 1; then compound 3.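

On an aromatic nitrogen of the five-membered aromatic ring with 3 nitrogen, the group carried matters in this assay: (5-(hydroxymethyl)-2,2-dimethyl-1,3-dioxolan-4-yl)methyl in place of 3,4-dihydroxy-5-(hydroxymethyl)oxolan-2-yl brings a 2.2-fold lower number from compound 1 to compound 4 (0.33 log units; beyond the scatter) as a modest step. The entering group has fewer hydrogen-bond donors, and the number does not rise with that loss. No measurement offered here accounts for the step. The change alters the ring, the donors and the stereocentres at once, and these cannot be told apart. As far as these compounds go, how an amine or a carboxylic acid at this place would read remains open.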